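Replacing chloro with azido on the shared core

A few compounds are considered here, and "the series" means these few. Any claim that something is new, unique, unknown or untested is made for them only; others in the source may bear on it.

Measured compounds:
compound 1, `OC[C@H]1OC(n2cnc3c(Nc4ccccc4)nccc32)[C@H](O)[C@@H]1O`: 10%
compound 2, `OC[C@H]1OC(n2cnc3c(Cl)nccc32)[C@H](O)[C@@H]1O`: < 5%

In a functional assay on EL4 cells (Mus musculus) for inhibition, tested at 100 uM (on this read-out lower numbers stand for less inhibition and higher numbers for more inhibition at the one concentration tested (going by the name of the read-out)), compound 2 gives < 5%; this is a limit of the assay and not a number (the limit of < 5% in this assay, at which 1 of the 2 values shown sits). Compound 1 gives 10% in this assay. Within the data shown here, the only measured step, a number at least 5 percentage points lower from compound 1 to compound 2 (that floor lies within the scatter), lies within the scatter and concerns anilino, not azido. Compound 3, `[N-]=[N+]=Nc1nccc2c1ncn2C1O[C@H](CO)[C@@H](O)[C@H]1O`, differs from compound 2 by azido in place of chloro on an aromatic carbon. Among the measured compounds shown here, no measured step bears on this change, so no step beyond the scatter is expected: a number no lower from compound 2 to compound 3 (the limit leaves the size open). Compound 3 is estimated at 5%, range 0% to 15%.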

Compound 3, a percentage reported as inhibition, at one concentration (the size of the read-out at that concentration, not a potency): < 5%
Compound 3 ended at the assay's limit; the forecaster's own chance of this, stated with the estimate: 50%; the middle value sits exactly at the limit.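

In this assay compound 3, with azido on the aromatic carbon next to the ring nitrogen, gives < 5%, a limit of the assay and not a number. Azido in place of anilino shows a number at least 5 percentage points lower from compound 1 to compound 3 (that floor lies within the scatter), so this change, like chloro before it, brings no step shown beyond the scatter. Azido and chloro cannot be ordered, as the step between them cannot be read: the limit of < 5% in this assay, at which 2 of the 3 values shown sit.

On these data alone, whether any group at this position reads clearly above the limit stays open. An alkylamine or a carboxylic acid there would test this.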